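Methyl for chloro on the aryl ring of compound 3

A few compounds are considered here, and "the series" means these few. Any claim that something is new, unique, unknown or untested is made for them only; others in the source may bear on it.

The set comprises three measured compounds sharing one core. Compound 1 `COc1ccccc1N1CCn2c1n[nH]c(=O)c2=O`, compound 2 `Cc1cccc(N2CCn3c2n[nH]c(=O)c3=O)c1C` and compound 3 `N=c1c(=O)[nH]nc2n1CCN2c1ccc(Cl)cc1` were tested in a functional assay on A549 cells (Homo sapiens) for antiproliferative activity, with a stated time of 72 h, tested at 50 ug/mL; a higher number here means a stronger effect of the compound at the concentration tested, a lower number a weaker effect. In this assay compound 1 gives 39%, compound 2 gives 0% and compound 3 gives 27%. Compound 3 thus stands second highest of the three numbers: its nearest neighbour is compound 1, whose value lies above it by more than the scatter, and its furthest is compound 2, whose value lies below it by a margin well beyond the scatter.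

The step from compound 3 leads to compound 4 `Cc1ccc(N2CCn3c2n[nH]c(=O)c3=N)cc1`, which has not yet been measured in this assay. The change is methyl in place of chloro on an aromatic carbon. No pair of measured compounds isolates this single change, so nothing on the shown numbers fixes its size. Because compound 2, which carries methyl groups on that ring, gives 0%, a modest loss is expected. The step expected in this assay is a number 7 percentage points lower from compound 3 to compound 4 (within the scatter). Compound 4 is estimated at 20%, with a range from 5% to 38%.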

Compound 4, a percentage reported as inhibition, at one concentration (the size of the read-out at that concentration, not a potency): 38%
Estimate against measurement, compound 4: 18 percentage points below; the measured number falls inside the stated range.
By their numbers in this assay, from the lowest: compound 2; then compound 3; then compounds 4 and 1 (each within the scatter of the next).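

In this assay, among the compounds shown here, methyl in place of chloro on an aromatic carbon, para to a large group, gives a number 11 percentage points higher from compound 3 to compound 4 (beyond the scatter) and is the only comparison here between compounds that differ in one place. The earlier compounds shown here differ from one another in more than one place, so they could not isolate what happens at this position. The result shows that chloro is not needed there for the effect at the tested concentration, and that methyl at this place gives a higher number on this core.

On these data alone, it remains open whether a fluoro, an amine, a carboxylic acid or a longer chain at this place would raise or lower the number further, and whether the step would hold with the group elsewhere on the ring. No measurement shown accounts for the direction or size of this step.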